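From 5-methylfuran-2-yl to 3-methylphenyl on a shared core

A few compounds are considered here, and "the series" means these few. Any claim that something is new, unique, unknown or untested is made for them only; others in the source may bear on it.

Results to date in a functional assay on HCT-15 cells (Homo sapiens) for cytotoxicity, read by ELISA, with a stated time of 4 days (on this read-out higher numbers stand for weaker inhibition and lower numbers for stronger inhibition), as follows
Compound 1 (`Cc1ccsc1-c1cc(-c2ccco2)cc(-c2ccc(Cl)cc2)n1`): 710 nM
Compound 2 (`Cc1ccc(-c2cc(-c3ccoc3)cc(-c3ccc(Cl)s3)n2)o1`): 790 nM

On these numbers compound 2 shares its level with compound 1. The two readings lie within the scatter of each other, so neither can be ranked, although the two compounds differ in more than one place. Compound 3 (`Cc1cccc(-c2cc(-c3ccoc3)cc(-c3ccc(Cl)s3)n2)c1`) has not yet been measured. It keeps the core of compound 2 but carries 3-methylphenyl in place of 5-methylfuran-2-yl on an aromatic carbon, next to the ring nitrogen (3-methylphenyl in place of 5-methylfuran-2-yl on an aromatic carbon). Among the measured compounds shown here, no pair of measured compounds differs in only one place, so the data offer no direct guide to this exchange. Compound 2 at 790 nM stays within the scatter of compound 1 despite their differences, and this is the only ground for expecting a small change in this assay here. Nothing beyond the scatter is expected, the estimate being a 1.1-fold higher number from compound 2 to compound 3 (0.06 log units; within the scatter) at its middle. Compound 3 is expected to read 900 nM by this estimate, with an estimated range from 350 nM to 2500 nM when tested.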

Compound 3, half-maximal inhibitory concentration: 880 nM
The estimate for compound 3 lay 1.0-fold (0.01 log units) above the measured number, and the stated range covers the measured number.
By their numbers in this assay, from the lowest: compounds 1, 2 and 3 (each within the scatter of the next).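

In this assay, among the compounds shown here, placing 3-methylphenyl in place of 5-methylfuran-2-yl on the aromatic carbon next to the ring nitrogen gives a 1.1-fold higher number from compound 2 to compound 3 (0.05 log units; within the scatter), and this is the first step that can be read as a change in one place. With the 5-chlorothiophen-2-yl and furan-3-yl groups held constant, a five-membered aromatic ring with one hetero atom and a six-membered aromatic ring of carbon only therefore read alike at this position, so the hetero atom of the leaving group is not required to keep the reading at this level. No evidence is available on why the two groups read alike.

The compounds shown leave open whether the same equivalence would hold with other groups at the two remaining aromatic positions, since this single pair tests the exchange only beside 5-chlorothiophen-2-yl and furan-3-yl. They also do not show whether a group of a different kind on this carbon, such as a primary amine, a carboxylic acid or a longer alkyl chain, would move the number beyond the scatter.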